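The source may report more compounds than this note shows. Statements on the series, on what has been measured and on what is new or still open speak of the compounds shown alone.

Compound 1, `N=C(NCCCc1c[nH]cn1)NCCCC(c1ccc(F)cc1)c1ccccn1`, in a functional assay on ileum for antagonist activity at histamine H1 receptor (Cavia porcellus) (a higher number here means weaker binding, a lower number tighter binding), gives 46.8 nM.
Compound 2, `Cc1ccc(C(CC/N=C(\N)NCCCc2c[nH]cn2)c2ccccn2)cc1`, in this assay gives 148 nM.
Compound 3, `N=C(NCCCc1c[nH]cn1)NCCC(c1ccc(F)cc1)c1ccccn1`, in this assay gives 22.4 nM.

Among these three compounds, compound 3 shows the lowest number in this assay. Its nearest neighbour is compound 1, whose number is higher by a margin that lies beyond the scatter, and compound 2 stands furthest away, also beyond the scatter. Compound 3 is therefore the tightest binder of the three on the numbers shown.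

Compound 4, `N=C(NCCCc1c[nH]cn1)NCCC(c1ccc(C(F)(F)F)cc1)c1ccccn1`, has not yet been measured in this assay. It differs from compound 3 in a single place: trifluoromethyl in place of fluoro on an aromatic carbon. For the measured compounds named here, no measured pair in this set shows the same change, so its size in this assay cannot be read from the data; the expectation rests only on compound 3 itself. The change is expected to shift the number modestly, most likely toward a somewhat weaker binding, though a result within the scatter of compound 3 would not be surprising. The step from compound 3 to compound 4 is estimated as a 1.8-fold higher number from compound 3 to compound 4 (0.25 log units; within the scatter). For compound 4 in this assay the estimate is 40 nM, with a range from 12 nM to 130 nM.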

Compound 4, dissociation constant: 282 nM
Compound 4: middle estimate off by 7.1-fold (0.85 log units), on the low side, and the stated range ends below it.
By their numbers in this assay, from the lowest: compound 3; then compound 1; then compounds 2 and 4 (each within the scatter of the next).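

For the compounds shown here, the change from fluoro to trifluoromethyl, on an aromatic carbon para to a large group, is the only single-place step that can be read in this set, and in this assay it produces a 13-fold higher number from compound 3 to compound 4 (1.10 log units; beyond the scatter) as a large loss of binding, well beyond the scatter. This shows that the position is not indifferent to what it carries: moving from 4-fluorophenyl to 4-(trifluoromethyl)phenyl, from one heavy atom to four, with no hydrogen-bond donor, acceptor or net charge entering or leaving, is enough to weaken binding markedly. Nothing available here bears on why this step is so large.

The compounds shown leave open how chloro, methoxy, nitrile or plain hydrogen would read at this same position, and therefore whether the loss belongs to trifluoromethyl alone or extends to other groups. They also leave open whether the same change would produce a step of similar size on the chain of compound 1.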